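Chlorophenyl Amide Expected Close to Its Fluoro Analogue

The source may hold more compounds than are shown below. What is called first, only, known or untested is meant among the compounds shown, and "the series" means these compounds.

In an ADME assay on HaCaT cells (Homo sapiens) for inhibition (a lower number here means a stronger inhibitor, a higher number a weaker inhibitor), compound 1 `COc1cc(-c2cc(C(=O)O)c3ccccc3n2)ccc1OCC(=O)Nc1ccccc1C` gives 230000 nM and compound 2 `COc1cc(-c2cc(C(=O)O)c3ccccc3n2)ccc1OCC(=O)Nc1cccc(C)c1` gives 225000 nM. Compound 3 `COc1cc(-c2cc(C(=O)O)c3ccccc3n2)ccc1OCC(=O)Nc1cccc(F)c1` gives 148000 nM in this assay; it holds the smallest of the three figures, yet the steps of a 1.6-fold lower number from compound 1 to compound 3 (0.19 log units; within the scatter) and a 1.5-fold lower number from compound 2 to compound 3 (0.18 log units; within the scatter) both lie within the scatter, so the three compounds are not separated. Compound 4 `COc1cc(-c2cc(C(=O)O)c3ccccc3n2)ccc1OCC(=O)Nc1ccc(Cl)cc1` differs from compound 3 by 4-chlorophenyl in place of 3-fluorophenyl on an amide-type nitrogen. Within the data shown here, the steps that bear on this change, a 1.0-fold lower number from compound 1 to compound 2 (0.01 log units; within the scatter), a 1.6-fold lower number from compound 1 to compound 3 (0.19 log units; within the scatter) and a 1.5-fold lower number from compound 2 to compound 3 (0.18 log units; within the scatter), each exchanged one substituted phenyl on the amide nitrogen for another and none moved the number beyond the scatter. Compound 4 is therefore expected to stay near compound 3, with a 1.1-fold higher number from compound 3 to compound 4 (0.06 log units; within the scatter). The estimate for compound 4 is 170000 nM, in the range 80000 nM to 360000 nM.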

Compound 4, half-maximal inhibitory concentration: > 300000 nM
Compound 4 ended at the assay's limit; the forecaster's own chance of this, stated with the estimate: 10%; at least 1.7-fold (0.24 log units) between middle value and limit.
By their numbers in this assay, from the lowest: compounds 3, 2 and 1 (each within the scatter of the next). At a limit, above all of these: compound 4.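

In this assay compound 4 gives > 300000 nM, which is a limit of the assay and not a number. It is the only compound shown to end at that limit: the limit of > 300000 nM in this assay, at which 1 of the 4 values shown sits. The steps of an at least 2.0-fold higher number from compound 3 to compound 4 (0.30 log units; that floor lies within the scatter), an at least 1.3-fold higher number from compound 2 to compound 4 (0.12 log units; that floor lies within the scatter) and an at least 1.3-fold higher number from compound 1 to compound 4 (0.11 log units; that floor lies within the scatter) are floors only, so this change on the amide-type nitrogen may move the number further than the earlier exchanges did, but the data do not establish that.

As far as these compounds go, whether 3-chlorophenyl or 4-fluorophenyl would stay near compound 3 or reach the limit remains open. So does the effect of an amine or a carboxylic acid on this phenyl.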